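Thiophene for benzofuran on a nucleoside core against K562 cells

The source may report more compounds than this note shows. Statements on the series, on what has been measured and on what is new or still open speak of the compounds shown alone.

The series rests on a shared core bearing a five-membered aromatic ring with one nitrogen in a fused system and a 3,4-dihydroxy-5-(hydroxymethyl)oxolan-2-yl group, read in a functional assay on K562 cells (Homo sapiens), read by MTT assay, with a stated time of 72 h; a lower number here means a stronger inhibitor, a higher number a weaker inhibitor. Compound 1 `O=c1[nH]cnc2c1c(-c1ccsc1)cn2[C@@H]1O[C@H](CO)[C@@H](O)[C@H]1O` reaches only the limit of the assay, > 20000 nM. Compound 2 `O=c1[nH]cnc2c1c(-c1cc3ccccc3o1)cn2[C@@H]1O[C@H](CO)[C@@H](O)[C@H]1O` likewise returns a limit, > 20000 nM. The change from compound 2 to compound 1 is thiophen-3-yl in place of 1-benzofuran-2-yl on an aromatic carbon, and the step that the two limits leave unreadable from compound 2 to compound 1 cannot be read, since both values sit at the limit of > 20000 nM in this assay, at which 2 of the 3 values shown sit. Within the data shown here, compound 3 `Cc1nc(N)c2c(-c3cc4ccccc4o3)cn([C@@H]3O[C@H](CO)[C@@H](O)[C@H]3O)c2n1` is the one compound with a number, giving 15700 nM. How the core of compound 3 differs from that of compound 2 is not broken down here. Compound 4 `Cc1nc(N)c2c(-c3ccsc3)cn([C@@H]3O[C@H](CO)[C@@H](O)[C@H]3O)c2n1` has not been measured. It differs from compound 3 by thiophen-3-yl in place of 1-benzofuran-2-yl on an aromatic carbon, the same kind of change as that from compound 2 to compound 1, made at a place described in the same words. Because the earlier step that the two limits leave unreadable from compound 2 to compound 1 is unreadable, the expectation for compound 4 is that a 1.6-fold higher number from compound 3 to compound 4 (0.20 log units; within the scatter) stays small and the value probably lands at or past the limit. Compound 4 is estimated at 25000 nM, between 8000 nM and 80000 nM.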

Compound 4, half-maximal inhibitory concentration: > 20000 nM
Compound 4: only a limit was reported (the forecaster's own chance of this, stated with the estimate: 60%); the middle value lies beyond the limit too.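

In this assay, compound 4 gives > 20000 nM, which is a limit of the assay and not a number. On the core of compound 3, thiophen-3-yl in place of 1-benzofuran-2-yl gives an at least 1.2-fold higher number from compound 3 to compound 4 (0.10 log units; that floor lies within the scatter), so this floor alone does not establish a real loss of activity, though a larger one is not excluded. The same change on the core of compound 2 cannot be read, and the size of the change therefore remains unknown on both cores, so the series shows only that no number was obtained with thiophen-3-yl on either core, not that the effect carries over with the same size, because the values concerned sit at the limit: the limit of > 20000 nM in this assay, at which 3 of the 4 values shown sit.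

The compounds shown leave open whether an amine or a carboxylic acid at this place on the core of compound 3 would give a number rather than a limit. They also leave open what a longer chain there would give, since only thiophen-3-yl and 1-benzofuran-2-yl appear at this place.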